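The source may hold more compounds than are shown below. What is called first, only, known or untested is meant among the compounds shown, and "the series" means these compounds.

Compound 1 `CC1=CC[C@H](C(C)(C)NC(=S)N/N=C/c2ccccc2O)CC1` serves as the reference point of this small set. In a functional assay on MCF7 cells (Homo sapiens) for inhibition, read by sulforhodamine B assay, with a stated time of 48 h (a higher number here means a weaker inhibitor of growth, a lower number a stronger inhibitor of growth), compound 1 gives 17500 nM, the lowest of the two numbers available; the nearest is compound 3 `CC1=CC[C@H](C(C)(C)NC(=S)N/N=C/c2cccc(Cl)c2)CC1`, which gives 61000 nM. Compound 2 `CC1=CC[C@H](C(C)(C)NC(=S)N/N=C/c2ccc(F)cc2)CC1` reached only a limit of the assay, > 100000 nM, so no number is known for it. Both measured steps replace the 2-hydroxyphenyl on the carbon with a double bond to nitrogen: an at least 5.7-fold higher number from compound 1 to compound 2 (0.75 log units; beyond the scatter) and a 3.5-fold higher number from compound 1 to compound 3 (0.54 log units; beyond the scatter). Between the two replacements the comparison shows an at least 1.6-fold lower number from compound 2 to compound 3 (0.21 log units; that floor lies within the scatter).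

Compound 4 `CC1=CC[C@H](C(C)(C)NC(=S)N/N=C/c2ccccc2[N+](=O)[O-])CC1` differs from compound 1 by nitro in place of hydroxy on an aromatic carbon. The two measured steps bear on this only loosely, since each moved to a different aryl substituent rather than swapping the hydroxy itself, but both weakened growth inhibition modestly or more once the hydroxy was gone. One would therefore expect compound 4 to be a weaker inhibitor than compound 1, with an estimated step of a 2.9-fold higher number from compound 1 to compound 4 (0.46 log units; beyond the scatter) in this assay, of a size like that seen toward compound 3. The estimate for compound 4 in this assay is 50000 nM, expected to fall between 15000 nM and 150000 nM, with a real chance that only a limit is reported.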

Compound 4, concentration for total growth inhibition: 94700 nM
Compound 4: the middle estimate sits 1.9-fold (0.28 log units) below what was measured; low and high end bracket the measured number.
By their numbers in this assay, from the lowest: compound 1; then compounds 3 and 4 (each within the scatter of the next). At a limit, above all of these: compound 2.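

Nitro in place of hydroxy on the same aromatic carbon, ortho to a large group, is the first change here that keeps the substituent's place fixed, and in this assay it gives a 5.4-fold higher number from compound 1 to compound 4 (0.73 log units; beyond the scatter). The earlier steps shown here changed the group and its place on the ring together, so they could not show whether simply having a substituent at this place was enough; compound 4 shows that it is not, at least for nitro. Hydroxy counts a hydrogen-bond donor and nitro counts none, but this single pair cannot tie that difference, or any other difference between the two groups, to the shift.

The compounds shown leave open how an amine or a methoxy group on this aromatic carbon would compare with hydroxy, which would help separate the donor count from the change of group itself. Compound 2 gives a limit and not a number, so the floor on its step leaves its true position open: the limit of > 100000 nM in this assay, at which 1 of the 4 values shown sits.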